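The source may report more compounds than this note shows. Statements on the series, on what has been measured and on what is new or still open speak of the compounds shown alone.

Two compounds share one core and differ only in the group sitting on a saturated chain carbon bound to an amine nitrogen. Compound 1 `Cc1ccc(CNC2(CCC(C)(C)C)C(=O)C(C3=NS(=O)(=O)c4cc(NS(C)(=O)=O)ccc4N3)=C(O)c3ccccc32)cn1` carries a 6-methylpyridin-3-yl there, and in an in vivo ADME assay on the whole organism (strain Sprague-Dawley) for pharmacokinetics, with Rattus norvegicus as the target, at a dose of 5 mg/kg by the intravenous route (on this read-out higher numbers stand for fast clearance and lower numbers for slow clearance), compound 1 gives 98.3 mL/min/kg. Compound 2 `COc1ccccc1CNC1(CCC(C)(C)C)C(=O)C(C2=NS(=O)(=O)c3cc(NS(C)(=O)=O)ccc3N2)=C(O)c2ccccc21` carries a 2-methoxyphenyl in its place, and in this assay compound 2 gives 25 mL/min/kg, the lowest of the two numbers; the swap brought a 3.9-fold lower number from compound 1 to compound 2 (0.59 log units; beyond the scatter). Compound 3 `Cc1cccc(C)c1CNC1(CCC(C)(C)C)C(=O)C(C2=NS(=O)(=O)c3cc(NS(C)(=O)=O)ccc3N2)=C(O)c2ccccc21` has not been measured. It differs from compound 2 by 2,6-dimethylphenyl in place of 2-methoxyphenyl on a saturated chain carbon bound to an amine nitrogen. Among the measured compounds shown here, no measured step exchanges these two groups, so the single known step at this position shows only that a change there can shift the clearance by a modest amount; it does not say which way a 2,6-dimethylphenyl will push it. The expectation for compound 3 is therefore a number close to that of compound 2, with wide room on both sides, and the expected step is a 1.4-fold higher number from compound 2 to compound 3 (0.15 log units; within the scatter). Compound 3 is estimated at 35 mL/min/kg, with a range from 15 mL/min/kg to 80 mL/min/kg.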

Compound 3, clearance: 13 mL/min/kg
Compound 3: middle estimate off by 2.7-fold (0.43 log units), on the high side; measured number below the stated range.
By their numbers in this assay, from the lowest: compounds 3 and 2 (each within the scatter of the next); then compound 1.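

In this assay, 2,6-dimethylphenyl in place of 2-methoxyphenyl gives a 1.9-fold lower number from compound 2 to compound 3 (0.28 log units; within the scatter). These two groups therefore cannot be told apart on this read-out, even though the hydrogen-bond acceptor counted on 2-methoxyphenyl is absent from 2,6-dimethylphenyl. The gap to the 6-methylpyridin-3-yl group now appears with a second group whose aromatic ring is carbon only, as 2,6-dimethylphenyl in place of 6-methylpyridin-3-yl gives a 7.6-fold lower number from compound 1 to compound 3 (0.88 log units; beyond the scatter), so among these three compounds, compound 1 is the only one that stands apart. No measurement shown here explains the separation of compound 1 from the other two compounds.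

Three compounds cannot show whether this separation follows the nitrogen in the ring of 6-methylpyridin-3-yl or some other difference between the groups, and a plain phenyl or a methoxypyridine ring at this place would help separate those possibilities. As far as these compounds go, it also remains open how clearance would respond to a quite different group on the saturated chain carbon bound to an amine nitrogen, such as a carboxylic acid or a longer chain.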